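Replacing a bromophenyl thiourea with a small urea group

This account rests on a few compounds, and the source may have more. Where it says the series, first, only, none or still open, it means among the compounds named here.

Measured compounds:
compound 1 `N#CC1=C(NC(=S)Nc2ccc(Cl)cc2)N(c2ccc(S(N)(=O)=O)cc2)C2=C(C(=O)CCC2)C1c1ccc(Cl)cc1Cl` — 40 ug/mL
compound 2 `N#CC1=C(NC(=S)Nc2ccc(Br)cc2)N(c2ccc(S(N)(=O)=O)cc2)C2=C(C(=O)CCC2)C1c1ccc(Cl)cc1Cl` — 25 ug/mL

In a functional assay on Ehrlich cells (Mus musculus) for cytotoxicity, read by trypan blue exclusion, with a stated time of 2 h (on this read-out lower numbers stand for stronger inhibition and higher numbers for weaker inhibition), compound 2 gives 25 ug/mL, the lowest of the two numbers recorded; its nearest neighbour is compound 1, and the move a 1.6-fold lower number from compound 1 to compound 2 (0.20 log units; within the scatter) stays within the scatter. Compound 3 `N#CC1=C(NC(N)=O)N(c2ccc(S(N)(=O)=O)cc2)C2=C(C(=O)CCC2)C1c1ccc(Cl)cc1Cl` has not been measured. It differs from compound 2 by a group of 3 heavy atoms (1 carbon, 1 nitrogen, 1 oxygen; no ring) in place of a group of 10 heavy atoms (7 carbon, 1 nitrogen, 1 sulfur, 1 bromine; one six-membered aromatic ring of carbon only), on an amine nitrogen. Among the compounds with values here, the only measured step, a 1.6-fold lower number from compound 1 to compound 2 (0.20 log units; within the scatter), swaps one halogen for another on the aromatic ring; it says nothing about removing that whole ring together with the thiourea sulfur and putting a bare carbamoyl group in its place. Within the data shown here, with no step bearing on such a change, the expectation for compound 3 rests mainly on the size of the loss, and the number is expected to move upward, that is toward weaker inhibition, by about a 2.4-fold higher number from compound 2 to compound 3 (0.38 log units; beyond the scatter). The estimate for compound 3 in this assay is 60 ug/mL, with a range from 20 ug/mL to 200 ug/mL.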

Compound 3, half-maximal inhibitory concentration: 75 ug/mL
The estimate for compound 3 lay 1.3-fold (0.10 log units) below the measured number, within the range that was stated.
By their numbers in this assay, from the lowest: compounds 2, 1 and 3 (each within the scatter of the next, the first and the last beyond it).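

In this assay, the amine nitrogen keeps a measurable effect even when the whole arm carrying the aromatic ring is replaced by a small carbamoyl group, a change that gives a 3.0-fold higher number from compound 2 to compound 3 (0.48 log units; beyond the scatter). The same replacement measured against the chlorine-bearing compound gives a 1.9-fold higher number from compound 1 to compound 3 (0.27 log units; within the scatter), so the loss clears the usual scatter against only one of the two halogen compounds, and this large structural change has only a modest effect on the number. No measurement is available to explain this result.

From the compounds shown here alone, the ring and the thiourea sulfur left together, so their separate contributions remain open. A phenyl urea or an unsubstituted thiourea on the same nitrogen would tell these two parts apart.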